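Methoxy to hydroxy in two matched urea pairs

The source may report more compounds than this note shows. Statements on the series, on what has been measured and on what is new or still open speak of the compounds shown alone.

Of the compounds shown here, three sharing one core have been measured, and a fourth has not. Compound 1 `COc1cc(-c2nn(-c3cccc(NC(=O)Nc4cc(C(F)(F)F)cc(C(F)(F)F)c4)c3)cc2-c2ccncc2)ccc1Cl` carries a methoxy group on its chlorophenyl ring. In a functional assay on UACC-257 cells (Homo sapiens) for inhibition, read by sulforhodamine B assay, with a stated time of 48 h (on this read-out lower numbers stand for stronger inhibition of growth and higher numbers for weaker inhibition of growth), compound 1 gives 2350 nM. Compound 2 `O=C(Nc1cccc(-n2cc(-c3ccncc3)c(-c3ccc(Cl)c(O)c3)n2)c1)Nc1cc(C(F)(F)F)cc(C(F)(F)F)c1` differs from it by hydrogen in place of methyl on an oxygen on an aromatic ring and in this assay compound 2 gives 2550 nM, so that a 1.1-fold higher number from compound 1 to compound 2 (0.04 log units; within the scatter). Compound 3 `COc1cc(-c2nn(-c3cccc(NC(=O)Nc4ccc(Cl)c(C(F)(F)F)c4)c3)cc2-c2ccncc2)ccc1Cl` keeps the methoxy group but carries a different urea substituent; in this assay compound 3 gives 6030 nM, the highest of the three numbers. The difference between the cores of compound 1 and compound 3 is not broken down here.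

Compound 4 `O=C(Nc1cccc(-n2cc(-c3ccncc3)c(-c3ccc(Cl)c(O)c3)n2)c1)Nc1ccc(Cl)c(C(F)(F)F)c1` has yet to be measured. It differs from compound 3 by hydrogen in place of methyl on an oxygen on an aromatic ring, the same change as between compound 1 and compound 2, at the same place. Because the earlier step was a 1.1-fold higher number from compound 1 to compound 2 (0.04 log units; within the scatter), compound 4 is expected to sit close to compound 3, with an expected step of a 1.1-fold higher number from compound 3 to compound 4 (0.03 log units; within the scatter). In this assay compound 4 is therefore estimated at 6500 nM, expected to fall between 3000 nM and 14000 nM.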

Compound 4, concentration for total growth inhibition: 2100 nM
The estimate for compound 4 lay 3.1-fold (0.49 log units) above the measured number, and the stated range ends above it.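

In this assay, the change from 4-chloro-3-methoxyphenyl to 4-chloro-3-hydroxyphenyl gave a 2.9-fold lower number from compound 3 to compound 4 (0.46 log units; beyond the scatter), so its effect did not carry over unchanged from the urea of compound 1 to the urea of compound 3: the same change on two cores in this assay, a 1.1-fold higher number (0.04 log units; within the scatter) from compound 1 to compound 2 and a 2.9-fold lower number (0.46 log units; beyond the scatter) from compound 3 to compound 4, 3.1-fold (0.49 log units) apart, beyond the scatter of two such steps. Within these two matched pairs, then, the step seen on one core did not foretell the step on the other, and a transfer of this change cannot be taken for granted in this series. The pairs do not show why the two steps differ, and two cores are too few to set a rule for when the change will leave the number unmoved and when it will lower it.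

The compounds shown leave open how the same change would behave with other urea substituents, such as a single trifluoromethyl group with no chlorine on that ring. They also leave open how an amine or an ethoxy group in place of the hydroxy would compare on either core.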